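The source may report more compounds than this note shows. Statements on the series, on what has been measured and on what is new or still open speak of the compounds shown alone.

Measured in a functional assay on MCF7 cells (Homo sapiens) for antiproliferative activity, read by MTT assay, with a stated time of 72 h; on this read-out higher numbers stand for weaker inhibition and lower numbers for stronger inhibition:
- compound 1 `COc1cc2c(Nc3ccc(C#N)cc3)ncnc2cc1OCCCN(C)Cc1ccccc1`: > 100000 nM, a limit of the assay
- compound 2 `COc1cc2c(Nc3ccc(C#N)cc3)ncnc2cc1OCCCN1CCCC1`: 16200 nM
- compound 3 `COc1cc2c(Nc3ccc(C#N)cc3)ncnc2cc1OCCCN1CCC(C)CC1`: 43100 nM

Only compound 2 and compound 3 have true numbers, and compound 3 has the higher one, 43100 nM, so it is the weaker of that pair. Compound 4 `COc1cc2c(Nc3ccc(C#N)cc3)ncnc2cc1OCCCN1CCC(O)CC1` alters one group of compound 3: hydroxy in place of methyl on a saturated ring carbon. This is hydroxy in place of methyl on a saturated ring carbon.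

Going by the values given here, no measured step makes this exact swap. The closest evidence comes from replacing the whole amine group at the end of the chain: a 2.7-fold higher number from compound 2 to compound 3 (0.42 log units; beyond the scatter), and an at least 2.3-fold lower number from compound 1 to compound 3 (0.36 log units; beyond the scatter). Both swaps are larger than the exchange of a single group on the ring, and a 2.7-fold higher number from compound 2 to compound 3 (0.42 log units; beyond the scatter) was still only modest. A small change in this assay is therefore expected, probably within the scatter and leaning slightly towards a lower number. The expected result is a 1.4-fold lower number from compound 3 to compound 4 (0.16 log units; within the scatter). For compound 4 the estimate is 30000 nM, with an expected range of 10000 nM to 90000 nM.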

Compound 4, half-maximal inhibitory concentration: > 100000 nM
Compound 4 gave a limit, no number; the forecaster's own chance of this, stated with the estimate: 15%; at least 3.3-fold (0.52 log units) between middle value and limit.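

On the saturated ring carbon three ring bonds from the ring nitrogen, the exchange of one atom is enough to weaken the result in this assay: hydroxy in place of methyl gives an at least 2.3-fold higher number from compound 3 to compound 4 (0.36 log units; beyond the scatter). Until now only the replacement of the whole amine group had moved the number beyond the scatter, and 4-hydroxypiperidin-1-yl in place of pyrrolidin-1-yl gives an at least 6.1-fold higher number from compound 2 to compound 4 (0.79 log units; beyond the scatter). Compound 1 and compound 4 both stand at the assay limit, so the step between them cannot be read: the limit of > 100000 nM in this assay, at which 2 of the 4 values shown sit.

On these data alone, how far above that limit compound 4 truly lies remains unknown. As far as these compounds go, it is also open whether methoxy or an amine at this ring carbon would behave like hydroxy or like methyl, and whether hydroxy would weaken the result on a pyrrolidin-1-yl ring too.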